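Fluorophenyl swap from compound 1 to compound 3

This account rests on a few compounds, and the source may have more. Where it says the series, first, only, none or still open, it means among the compounds named here.

For the measured compounds named here, in a functional assay on HepG2 cells (Homo sapiens) for cytotoxicity, read by MTT assay, with a stated time of 24 h (a lower number here means a stronger inhibitor, a higher number a weaker inhibitor), compound 1 (`CN1C/C(=C\c2cccc([N+](=O)[O-])c2)C(=O)/C(=C/c2ccccc2F)C1`) gives 1080 nM and holds the lower of the two numbers measured so far. Compound 2 (`COc1cc(/C=C2\CN(C)C/C(=C\c3ccc(Cl)cc3Cl)C2=O)cc(OC)c1OC`) at 8800 nM lies above it by a gap beyond the scatter. Compound 3 (`CN1C/C(=C\c2ccc(F)cc2)C(=O)/C(=C/c2cccc([N+](=O)[O-])c2)C1`) is the next to be read. It carries 4-fluorophenyl in place of 2-fluorophenyl on a double-bonded chain carbon bound to a double-bonded ring carbon. The leaving and entering groups match in every counted feature. Going by the values given here, compound 1 and compound 2 differ in more than one place, so no measured step isolates this swap. The expected step in this assay is therefore small, estimated at a 1.4-fold higher number from compound 1 to compound 3 (0.14 log units; within the scatter) and expected to stay within the scatter, with a slight lean toward a higher number. That lean rests only on compound 1 at 1080 nM being the lower of the two values, and it is weak evidence. For compound 3 the estimated value is 1500 nM with an expected range from 500 nM to 5000 nM in these notes.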

Compound 3, half-maximal inhibitory concentration: 9340 nM
Compound 3: middle estimate off by 6.2-fold (0.79 log units), on the low side; measured number above the stated range.
By their numbers in this assay, from the lowest: compound 1; then compounds 2 and 3 (each within the scatter of the next).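

In this assay the change to 4-fluorophenyl in place of 2-fluorophenyl on a double-bonded chain carbon bound to a double-bonded ring carbon gives an 8.6-fold higher number from compound 1 to compound 3 (0.94 log units; beyond the scatter) even though the leaving and entering groups match in every counted feature. This place on the shared core is therefore not indifferent to the swap: the location of the fluorine on this phenyl alone accounts for a step beyond the scatter, something compound 1 and compound 2 could not show, as they differ in more than one place. Nothing measured here bears on the reason for this step.

A single step leaves open whether the higher number is specific to 4-fluorophenyl or follows from losing 2-fluorophenyl, a question that 3-fluorophenyl, unsubstituted phenyl or 2-chlorophenyl at the same place would help to settle. Also open, as far as these compounds go, is whether the swap gives a step of similar size when the nitrophenyl of compound 1 is exchanged for another group, such as a pyridyl or a methoxyphenyl.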